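The source may report more compounds than this note shows. Statements on the series, on what has been measured and on what is new or still open speak of the compounds shown alone.

Measured in an ADME assay on Caco-2 cells (Homo sapiens) for permeability, read by LC-MS, in the apical to basolateral direction, with a stated time of 60 min, at pH 6.5; a higher number here means that the compound crosses the layer faster, a lower number that the compound crosses the layer more slowly:
- compound 1 `CC(C)(C)OC[C@@H](O)C(=O)N1[C@H](C(=O)NCc2cc(Cl)ccc2-n2cnnn2)C[C@@H]2C[C@@H]21`: 4.5 10^-6 cm/s
- compound 2 `O=C(NCc1cc(Cl)ccc1-n1cnnn1)[C@@H]1CCNN1C(=O)[C@H](O)c1ccccc1`: 5.3 10^-6 cm/s
- compound 3 `O=C(NCc1cc(Cl)ccc1-n1cnnn1)[C@@H]1C[C@H]2C[C@H]2N1C(=O)[C@H](O)c1ccccc1`: 17 10^-6 cm/s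

Compound 2 lies within the usual scatter of compound 1, while compound 3 reads higher, beyond that scatter. Compound 4 `CC(C)(C)C[C@@H](O)C(=O)N1NCC[C@H]1C(=O)NCc1cc(Cl)ccc1-n1cnnn1` has not yet been measured. It departs from compound 2 by neopentyl in place of phenyl on a saturated chain carbon bound to a carbonyl carbon and an oxygen on a saturated carbon. Among the measured compounds shown here, no measured pair isolates this change in this assay. Compound 1 also holds no phenyl and gives 4.5 10^-6 cm/s, so no shift beyond the scatter is expected. The estimated step of a 1.1-fold higher number from compound 2 to compound 4 (0.05 log units; within the scatter) is slightly upward and stays within the scatter. The estimate for compound 4 is 6 10^-6 cm/s, with an expected range from 2.5 10^-6 cm/s to 14 10^-6 cm/s.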

Compound 4, apparent permeability: 15 10^-6 cm/s
The estimate for compound 4 lay 2.5-fold (0.40 log units) below the measured number; the measured number lies above the stated range.
By their numbers in this assay, from the lowest: compounds 1 and 2 (each within the scatter of the next); then compounds 4 and 3 (each within the scatter of the next).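

In this assay, neopentyl in place of phenyl on a saturated chain carbon bound to a carbonyl carbon and an oxygen on a saturated carbon gives a 2.8-fold higher number from compound 2 to compound 4 (0.45 log units; beyond the scatter). Among the compounds shown here, this is the first single-place comparison at this position, and it shows that the number responds to this group and that an aromatic ring there is not needed for the higher reading. Nothing available explains the step.

The compounds shown leave open whether a cyclohexyl group or an isopropyl group at this carbon would read like neopentyl or like phenyl. They also leave open whether the same exchange would shift the number on the core of compound 3.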